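Trimming a methyl from a weak nucleoside transporter ligand

The source may report more compounds than this note shows. Statements on the series, on what has been measured and on what is new or still open speak of the compounds shown alone.

Three nucleoside analogues sharing one core have been measured in an assay on isolated protein for binding affinity to Equilibrative nucleoside transporter 1 (Homo sapiens); on this read-out higher numbers stand for weaker inhibition and lower numbers for stronger inhibition. Compound 1 `Nc1nc(SCc2ccc(F)cc2)c2ncn([C@@H]3O[C@H](CO)[C@@H](O)[C@H]3O)c2n1` gives 1150 nM. Compound 2 `CC(C)Sc1nc(N)nc2c1ncn2[C@@H]1O[C@H](CO)[C@@H](O)[C@H]1O` gives 191000 nM, a step of a 170-fold higher number from compound 1 to compound 2 (2.22 log units; beyond the scatter). Compound 3 `Cc1cccc(CSc2nc(N)nc3c2ncn3[C@@H]2O[C@H](CO)[C@@H](O)[C@H]2O)n1` gives 11500000 nM, the highest of the three numbers; its nearest neighbour is compound 2, with a 60-fold higher number from compound 2 to compound 3 (1.78 log units; beyond the scatter), and its furthest is compound 1, with a 10000-fold higher number from compound 1 to compound 3 (4.00 log units; beyond the scatter).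

Compound 4 `Nc1nc(SCc2ccccn2)c2ncn([C@@H]3O[C@H](CO)[C@@H](O)[C@H]3O)c2n1` has not yet been measured in this assay. It differs from compound 3 by hydrogen in place of methyl on an aromatic carbon. Among the compounds with values here, no measured step removes a methyl, so the closest guide is the change from compound 1 to compound 3, in which the whole 6-methylpyridin-2-yl group replaced 4-fluorophenyl with a very large rise in the number. Compound 4 keeps the pyridine but not the methyl, so part of that rise may be undone; the step from compound 3 to compound 4 is therefore expected to lower the number, by a 14-fold lower number from compound 3 to compound 4 (1.16 log units; beyond the scatter). Compound 4 is estimated at 800000 nM, within a range from 60000 nM to 8000000 nM.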

Compound 4, half-maximal inhibitory concentration: 34700 nM
Beside the measured number, compound 4's estimate is 23-fold (1.36 log units) above it, outside the stated range (below it).
By their numbers in this assay, from the lowest: compound 1; then compound 4; then compound 2; then compound 3.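

Removing a single methyl from the 6-methylpyridin-2-yl group reverses most of the loss seen in compound 3: in this assay the step is a 330-fold lower number from compound 3 to compound 4 (2.52 log units; beyond the scatter), while the gap left to the 4-fluorophenyl group is smaller, at a 30-fold higher number from compound 1 to compound 4 (1.48 log units; beyond the scatter). The pyridine ring itself therefore costs much less than the ring carrying a methyl next to the ring nitrogen. The methyl also decides how the pyridine side chain compares with isopropyl on the sulfur: without it the step is a 5.5-fold lower number from compound 2 to compound 4 (0.74 log units; beyond the scatter), a modest gain, whereas with it the step runs the other way, a 60-fold higher number from compound 2 to compound 3 (1.78 log units; beyond the scatter).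

The data offer no measured explanation for why one methyl has so large an effect. Going by these compounds, it remains open whether an ethyl, a methoxy or a chlorine at this position would behave like the methyl or like the hydrogen.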